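A few compounds are considered here, and "the series" means these few. Any claim that something is new, unique, unknown or untested is made for them only; others in the source may bear on it.

In a functional assay on MDA-MB-231 cells (Homo sapiens) for inhibition, read by MTT assay, with a stated time of 48 h (a higher number here means a weaker inhibitor, a lower number a stronger inhibitor), compound 1 (`COc1ccc(N(C)c2nc(C)nc3ccccc23)cc1OCCCCCC[Se]C#N`) gives 3550 nM, compound 2 (`COc1ccc(N(C)c2nc(C)nc3ccccc23)cc1[Se]C#N`) gives 52 nM and compound 3 (`COc1ccc(N(C)c2nc(C)nc3ccccc23)cc1C[Se]C#N`) gives 153 nM, which places compound 3 second highest of the three. Compound 4 (`COc1ccc(N(C)c2nc(C)nc3ccccc23)cc1OCCN`) departs from it by a group of 4 heavy atoms (2 carbon, 1 nitrogen, 1 oxygen; no ring) in place of a group of 4 heavy atoms (2 carbon, 1 nitrogen, 1 selenium; no ring), on an aromatic carbon, the entering group being 2-aminoethoxy, ortho to a methoxy group. Among the measured compounds shown here, two measured steps bear on this change: the modest 2.9-fold higher number from compound 2 to compound 3 (0.47 log units; beyond the scatter) and the large 23-fold lower number from compound 1 to compound 3 (1.37 log units; beyond the scatter). For the measured compounds named here, no measured compound lacks the selenium, so these steps guide the size only loosely, and the range must stay wide. A modest move toward a weaker inhibitor is expected, a 2.0-fold higher number from compound 3 to compound 4 (0.29 log units; within the scatter). For compound 4 the estimated value is 300 nM, with an expected range of 60 nM to 1500 nM.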

Compound 4, half-maximal inhibitory concentration: 682 nM
Estimate against measurement, compound 4: 2.3-fold (0.36 log units) below; low and high end bracket the measured number.
By their numbers in this assay, from the lowest: compound 2; then compound 3; then compound 4; then compound 1.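

In this assay, a group without selenium still gives a measurable inhibitor at this position: 2-aminoethoxy gives a 5.2-fold lower number from compound 1 to compound 4 (0.72 log units; beyond the scatter), yet trails the two short selenium groups, with a 4.5-fold higher number from compound 3 to compound 4 (0.65 log units; beyond the scatter) and a 13-fold higher number from compound 2 to compound 4 (1.12 log units; beyond the scatter). Chain size alone therefore does not set the order among these compounds. Nothing measured here explains this order. On these data alone, whether the weakening follows the loss of selenium or the change in the linking atoms stays open. So does how a longer chain ending in an amine, or a carboxylic acid, would read here.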